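The compounds below may be only part of what the source reports. "The series", "measured", "known", "first", "only" and "open" are said of these compounds alone.

Compound 2 `CC(C)(C)c1ccc(C(=O)N2CCC3(CC2)C(=O)N(CC(=O)N2CCCCC2CCO)CN3c2ccccc2)cc1` is the weakest-looking of the three measured compounds: in an assay on HEK293 cells for displacement of a labelled ligand from NPC1-like intracellular cholesterol transporter 1 (Homo sapiens) (a higher number here means a weaker inhibitor, a lower number a stronger inhibitor), compound 2 gives 6100 nM, the highest number of the set. Compound 3 `CC(C)(C)OC(=O)NCCCCNC(=O)CN1CN(c2ccccc2)C2(CCN(C(=O)c3ccc(C4CCCCC4)cc3)CC2)C1=O` gives 4600 nM, which lies within the scatter of compound 2, while compound 1 `O=C(CN1CN(c2ccccc2)C2(CCN(C(=O)c3ccc(C4CCCCC4)cc3)CC2)C1=O)N1CCCCC1` gives 1100 nM, a lower number that is beyond the scatter. Compound 4 `CC(C)(C)c1ccc(C(=O)N2CCC3(CC2)C(=O)N(CC(=O)NCCCNS(C)(=O)=O)CN3c2ccccc2)cc1` has not been measured. It differs from compound 2 by (3-(methanesulfonamido)propyl)amino in place of 2-(2-hydroxyethyl)piperidin-1-yl on a carbonyl carbon. Within the data shown here, no step between two measured compounds that differ in one place exists here, so the size of this change can only be guessed. Compound 4 is expected to sit close to compound 2, with a 1.2-fold lower number from compound 2 to compound 4 (0.09 log units; within the scatter) not clearly beyond the scatter. The estimate for compound 4 in this assay is 5000 nM, between 2000 nM and 15000 nM.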

Compound 4, half-maximal inhibitory concentration: 10400 nM
Compound 4: middle estimate off by 2.1-fold (0.32 log units), on the low side; measured number inside the range.
By their numbers in this assay, from the lowest: compound 1; then compounds 3, 2 and 4 (each within the scatter of the next, the first and the last beyond it).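

In this assay, among these compounds, the first readable step at this position, (3-(methanesulfonamido)propyl)amino in place of 2-(2-hydroxyethyl)piperidin-1-yl on a carbonyl carbon, is a 1.7-fold higher number from compound 2 to compound 4 (0.23 log units; within the scatter) and so cannot be told apart from repeat-measurement noise. At this position, then, an open chain with no ring can stand in for a six-membered non-aromatic ring of the same heavy-atom count without a clear shift in the number. Nothing available explains this outcome. Still open, from the compounds shown here alone, is whether a carboxylic acid or an amine in place of the methanesulfonamido end, or a longer chain, would give a step beyond the scatter.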